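Methyl on the hydroxy oxygen of compound 1

A few compounds are considered here, and "the series" means these few. Any claim that something is new, unique, unknown or untested is made for them only; others in the source may bear on it.

Compound 1 (`O=C(NCCCNc1cc(-c2cn(-c3ccccc3)nc2-c2cccc(O)c2)ccn1)Nc1ccc(F)cc1`) gives (2350 nM)
Compound 2 (`O=C(NCCCNc1cc(-c2cn(-c3ccccc3)nc2-c2cccc(O)c2)ccn1)Nc1cccc(C(F)(F)F)c1`) gives (3480 nM)

Going by the values given here, in a functional assay on NCI-H460 cells (Homo sapiens) for antiproliferative activity, read by sulforhodamine B assay, with a stated time of 48 h (on this read-out higher numbers stand for weaker inhibition and lower numbers for stronger inhibition), compound 1 stands level with compound 2, the only other compound measured, and the gap between them is (a 1.5-fold higher number from compound 1 to compound 2 (0.17 log units; within the scatter)). Compound 3 (`COc1cccc(-c2nn(-c3ccccc3)cc2-c2ccnc(NCCCNC(=O)Nc3ccc(F)cc3)c2)c1`) differs from compound 1 in one place (methyl in place of hydrogen on an oxygen on an aromatic ring), which reads as hydroxy to methoxy, or 3-hydroxyphenyl to 3-methoxyphenyl. Among the compounds with values here, the one measured step (a 1.5-fold higher number from compound 1 to compound 2 (0.17 log units; within the scatter)) concerns a different place, an amide-type nitrogen, and so gives no direct guide to this oxygen. Within the data shown here, no measured pair shows this change, so the data offer no direction and no shift beyond the scatter is expected in this assay. The expectation therefore stays anchored on compound 1 (2350 nM). The expected step is (a 1.3-fold higher number from compound 1 to compound 3 (0.11 log units; within the scatter)). Compound 3 is estimated at (3000 nM), with an expected range from (1000 nM) to (9000 nM).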

Compound 3, half-maximal inhibitory concentration: 6540 nM
Compound 3: middle estimate off by 2.2-fold (0.34 log units), on the low side; measured number inside the range.
By their numbers in this assay, from the lowest: compounds 1, 2 and 3 (each within the scatter of the next, the first and the last beyond it).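

In this assay, putting a methyl on the hydroxy oxygen gives a step beyond the scatter (a 2.8-fold higher number from compound 1 to compound 3 (0.44 log units; beyond the scatter)), so the change from hydroxy to methoxy on this aromatic ring registers, in the direction of weaker inhibition. The earlier step concerned only the amide-type nitrogen and stayed within the scatter, so this oxygen is the one place shown where a single change moves the number beyond it, though only modestly. Nothing available explains this shift.

Going by these compounds, the finding rests on a single pair, so it remains open whether an ethoxy group, or an amine or a carboxylic acid in place of the hydroxy group, would move the number the same way. On these data alone, it is also open whether the same step would appear with the 3-(trifluoromethyl)phenyl group of compound 2.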